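Adding methoxycarbonyl to compound 2

A few compounds are considered here, and "the series" means these few. Any claim that something is new, unique, unknown or untested is made for them only; others in the source may bear on it.

Compound 1 `Cc1ncnc(C)c1C(=O)N1C[C@H]2CN(CC[C@H](NC(=O)C3CCOC3)c3ccccc3)C[C@H]2C1` gives 17 mL.min-1.g-1 in an in vitro ADME assay on microsomes from liver (Homo sapiens) for pharmacokinetics; on this read-out higher numbers stand for fast clearance and lower numbers for slow clearance
Compound 2 `CC(=O)N[C@@H](CCN1C[C@@H]2CN(C(=O)c3ccccc3)C[C@@H]2C1)c1ccccc1` gives 70 mL.min-1.g-1 in this assay

Compound 2 stands highest of the two, and its gap to compound 1 lies beyond the scatter of repeated measurements. Within the data shown here, these two compounds differ in more than one place, so no measured pair shows what a single change does here.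

Compound 3 `COC(=O)c1ccc(C(=O)N2C[C@H]3CN(CC[C@H](NC(C)=O)c4ccccc4)C[C@H]3C2)cc1` is compound 2 with one change: methoxycarbonyl in place of hydrogen on an aromatic carbon, para to a large group methoxycarbonyl in place of hydrogen on an aromatic carbon which turns phenyl to 4-(methoxycarbonyl)phenyl. The rest of the molecule stays the same, so the number for compound 2 is the natural starting point. Among the measured compounds shown here, with no measured single step to guide it, the expectation in this assay is only a slight rise, possibly none beyond the scatter. The expected change is a 1.2-fold higher number from compound 2 to compound 3 (0.08 log units; within the scatter) and the range around it is kept wide. For compound 3 the estimated value is 85 mL.min-1.g-1 and it is expected to fall between 35 mL.min-1.g-1 and 200 mL.min-1.g-1.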

Compound 3, intrinsic clearance in microsomes: 77 mL.min-1.g-1
Compound 3: middle estimate off by 1.1-fold (0.04 log units), on the high side; the measured number falls inside the stated range.
By their numbers in this assay, from the lowest: compound 1; then compounds 2 and 3 (each within the scatter of the next).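

In this assay, methoxycarbonyl in place of hydrogen on an aromatic carbon, para to a large group, gives a 1.1-fold higher number from compound 2 to compound 3 (0.04 log units; within the scatter) and so leaves no readable difference between the two compounds. Among these compounds, this is the first single change that can be read in this set, and it shows that a group of this size can enter at this place on the phenyl ring, turning it into 4-(methoxycarbonyl)phenyl, without moving clearance in human liver microsomes beyond the ordinary spread of repeat measurements. Nothing available here explains why the number holds, so the result stands as an observation only.

On these data alone, one step at one place says little about other groups, and it remains open whether a carboxylic acid, an amine or a longer chain such as ethoxycarbonyl in the same place would give a number that differs beyond the scatter. As far as these compounds go, it is also open whether methoxycarbonyl would behave the same way on another carbon of this ring, or on the ring carried by compound 1, which differs from compound 2 in more than one place.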